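Propoxy for Methoxy on Two Cores: Tolerance in Kidney Cells

The source may report more compounds than this note shows. Statements on the series, on what has been measured and on what is new or still open speak of the compounds shown alone.

Measured so far:
compound 1, `CCCOc1nc(CC2(c3ccccc3)CO2)cc(=O)n1C`: > 330000 nM
compound 2, `COc1nc(CC2(c3ccccc3)CO2)cc(=O)n1C`: > 360000 nM
compound 3, `COc1nc(CC2(C)CCCO2)cc(=O)n1C`: 1620000 nM

Of the compounds shown here, three have been tested in a functional assay on MDCK cells (Canis lupus familiaris) for inhibition; a higher number here means that more compound is tolerated, a lower number that less compound is tolerated. Compound 1 reached only a limit of the assay, > 330000 nM. Compound 2 likewise stopped at a limit, > 360000 nM. Within the data shown here, compound 3 is the one compound of the three with a number: in this assay compound 3 gives 1620000 nM.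

Compound 1 differs from compound 2 by ethyl in place of hydrogen on a saturated chain carbon bound to an oxygen on an aromatic ring. The step that the two limits leave unreadable from compound 2 to compound 1 cannot be read, because both values are limits (the limit of > 330000 nM in this assay, at which 1 of the 3 values shown sits, and (the limit of > 360000 nM in this assay, at which 1 of the 3 values shown sits)). The core of compound 3 differs from that of compound 2, and the difference between the two cores is not broken down here.

Compound 4, `CCCOc1nc(CC2(C)CCCO2)cc(=O)n1C`, has not yet been measured. It differs from compound 3 by ethyl in place of hydrogen on a saturated chain carbon bound to an oxygen on an aromatic ring, the same change that leads from compound 2 to compound 1. Among the measured compounds shown here, since that earlier instance gives no readable size, the expectation rests on compound 3 alone, whose value 1620000 nM is the only number available. Compound 4 is therefore expected to come out near compound 3, estimated at 1000000 nM. The range expected for compound 4 runs from 300000 nM to 3000000 nM. The step of a 1.6-fold lower number from compound 3 to compound 4 (0.21 log units; within the scatter) is the estimated outcome of this change.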

Compound 4, half-maximal cytotoxic concentration: 860000 nM
Estimate against measurement, compound 4: 1.2-fold (0.07 log units) above; the measured number falls inside the stated range.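

On the core of compound 3, the change from methoxy to propoxy can now be read in this assay (a 1.9-fold lower number from compound 3 to compound 4 (0.28 log units; within the scatter)), so on this core the two compounds cannot be told apart in this assay, and this single step is all that the series offers as a size for the change. Compound 1 stands at a limit of the assay, > 330000 nM, and so gives no size for the change on its core. Among these compounds, compound 2 is likewise held at a limit, > 360000 nM, so the one readable step has no second step to be set against, and the data show neither that the change carries over from one core to the other nor that it fails to.

The compounds shown leave open whether a longer chain, such as butoxy in place of propoxy, would give a step beyond the scatter on the core of compound 3. Equally open, on these data alone, is how a propoxy chain ending in an amine or a carboxylic acid would fare on that core, and whether such a group on the core of compound 2 would yield a number rather than a limit.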